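A few compounds are considered here, and "the series" means these few. Any claim that something is new, unique, unknown or untested is made for them only; others in the source may bear on it.

Measured so far in a functional assay on the whole organism (strain Jcl:Sprague-Dawley) for inhibition, with Rattus norvegicus as the target, with stated times of 3 min and 3 h, at a dose of 1 mg/kg by the intravenous route; a higher number here means more inhibition at the dose given (going by the name of the read-out), a lower number less inhibition:
compound 1 `CNCc1cn(S(=O)(=O)c2ccccn2)c(-c2cccnc2F)c1F` gives 95%
compound 2 `CNCc1cn(S(=O)(=O)c2cc(OC)ccn2)c(-c2cccnc2F)c1F` gives 95%

Compound 2 stands level with compound 1 at the digits shown; the step of no change at the digits printed from compound 1 to compound 2 (within the scatter) lies within the scatter. Compound 3 `CNCc1cn(S(=O)(=O)c2ccc(OC)cn2)c(-c2cccnc2F)c1F` differs from compound 2 by 5-methoxypyridin-2-yl in place of 4-methoxypyridin-2-yl on a sulfonyl sulfur; the two have the same atoms, joined differently. Going by the values given here, the only measured step that bears on a methoxy on the ring at the sulfonyl sulfur is no change at the digits printed from compound 1 to compound 2 (within the scatter), and it was within the scatter, so no step beyond the scatter is expected here either, in either direction. Compound 3 is therefore expected to give 93%, between 80% and 99%, a step of a number 2 percentage points lower from compound 2 to compound 3 (within the scatter) expected to stay within the scatter.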

Compound 3, a percentage reported as inhibition, in the whole organism at one dose (the size of the read-out at that dose, not a potency): 95%
For compound 3 the middle estimate is 2 percentage points below the measured one; low and high end bracket the measured number.
By their numbers in this assay, from the lowest: compounds 1, 2 and 3 (each within the scatter of the next).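

In this assay, moving the methoxy on the ring at the sulfonyl sulfur gives no change at the digits printed from compound 2 to compound 3 (within the scatter), so this read-out at one dose does not separate 5-methoxypyridin-2-yl from 4-methoxypyridin-2-yl. Methoxy in place of hydrogen at this second ring carbon gives no change at the digits printed from compound 1 to compound 3 (within the scatter), a second such step alongside the earlier one. Nothing at hand accounts for these results.

Going by these compounds, whether a carboxylic acid or a dimethylamino group on this ring would hold the read-out in this assay stays open. Any difference in potency among these compounds also stays open, as a single dose does not give one.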